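A few compounds are considered here, and "the series" means these few. Any claim that something is new, unique, unknown or untested is made for them only; others in the source may bear on it.

The series shares one core carrying an amide-linked chain that ends in a cyclic amine. Compound 1 `O=C(/C=C/CN1CCCC1)Nc1cc2c(N3CCc4ccccc43)ncnc2cc1O[C@@H]1CCOC1` is the reference point; in a functional assay on PC-3 cells (Homo sapiens) for antiproliferative activity, read by MTT assay, with a stated time of 72 h (a higher number here means a weaker inhibitor, a lower number a stronger inhibitor), compound 1 gives 1510 nM. Compound 2 `O=C(/C=C/CN1CCCCC1)Nc1cc2c(N3CCc4ccccc43)ncnc2cc1O[C@@H]1CCOC1` carries piperidin-1-yl in place of pyrrolidin-1-yl on a saturated chain carbon bound to a double-bonded chain carbon; in this assay compound 2 gives 4510 nM, a step of a 3.0-fold higher number from compound 1 to compound 2 (0.48 log units; beyond the scatter). Compound 3 `O=C(/C=C/CN1CCCC1)Nc1cc2c(N3CCCc4ccccc43)ncnc2cc1O[C@@H]1CCOC1` differs from compound 1 in the core, (1,2,3,4-tetrahydroquinolin-1-yl in place of 2,3-dihydro-1H-indol-1-yl on an aromatic carbon); in this assay compound 3 gives 5780 nM, a step of a 3.8-fold higher number from compound 1 to compound 3 (0.58 log units; beyond the scatter). Compound 4 `O=C(/C=C/CN1CCCCC1)Nc1cc2c(N3CCCc4ccccc43)ncnc2cc1O[C@@H]1CCOC1` joins the core of compound 3 with the amine of compound 2: piperidin-1-yl in place of pyrrolidin-1-yl on a saturated chain carbon bound to a double-bonded chain carbon. This is the same change as that from compound 1 to compound 2, and the place of the change is the same word for word. For the measured compounds named here, no measured pair shows whether the two changes add up. Going by the values given here, the step from compound 3 to compound 4 is expected to be about a 2.6-fold higher number from compound 3 to compound 4 (0.41 log units; beyond the scatter), resting on a 3.0-fold higher number from compound 1 to compound 2 (0.48 log units; beyond the scatter) as the only precedent for this change in this assay, with some allowance for a smaller than additive outcome. Compound 4 is estimated at 15000 nM in this assay, with a likely range from 6000 nM to 40000 nM.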

Compound 4, half-maximal inhibitory concentration: 3630 nM
Compound 4: the middle estimate sits 4.1-fold (0.62 log units) above what was measured, outside the stated range (below it).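

With 1,2,3,4-tetrahydroquinolin-1-yl on the core, piperidin-1-yl in place of pyrrolidin-1-yl gives a 1.6-fold lower number from compound 3 to compound 4 (0.20 log units; within the scatter) in this assay, so the step seen with 2,3-dihydro-1H-indol-1-yl on the core does not carry over: the same change on two cores in this assay, a 3.0-fold higher number (0.48 log units; beyond the scatter) from compound 1 to compound 2 and a 1.6-fold lower number (0.20 log units; within the scatter) from compound 3 to compound 4, 4.8-fold (0.68 log units) apart, beyond the scatter of two such steps

With piperidin-1-yl on the chain, the matching core change gives a 1.2-fold lower number from compound 2 to compound 4 (0.09 log units; within the scatter), so the core change does not hold its size either: the same change on two cores in this assay, a 3.8-fold higher number (0.58 log units; beyond the scatter) from compound 1 to compound 3 and a 1.2-fold lower number (0.09 log units; within the scatter) from compound 2 to compound 4, 4.8-fold (0.68 log units) apart, beyond the scatter of two such steps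

These four compounds therefore show that the two changes do not add up here, but this single set, read in one assay, does not show why or whether the same holds for other amines or cores.

Open, on these data alone, is how morpholin-4-yl or dimethylamino would read on each of the two cores, placed on a saturated chain carbon bound to a double-bonded chain carbon. Also open, as far as these compounds go, is whether the gap between the two steps would recur with those amines.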